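This account rests on a few compounds, and the source may have more. Where it says the series, first, only, none or still open, it means among the compounds named here.

Compound 1 `CCN(CC)c1cc2[nH]c(C3CCCCC3)nc2cc1NC(=O)OCCOCCOC` gives only the limit > 100 ug/mL in an ADME assay on Vero cells (Chlorocebus sabaeus) for cytotoxicity, read by resazurin assay, with a stated time of 3 days (a higher number here means a weaker inhibitor, a lower number a stronger inhibitor), not a number.
Compound 2 `CN(C)c1cc2[nH]c(C3CCCCC3)nc2cc1NC(=O)c1cccs1` gives only the limit > 100 ug/mL in this assay.
Compound 3 `COc1ccc(C(=O)Nc2cc3nc(C4CCCCC4)[nH]c3cc2N(C)C)cc1` gives only the limit > 100 ug/mL in this assay.

Compound 1 therefore stands nowhere on a scale of numbers: all three compounds sit at the limit of > 100 ug/mL in this assay, at which 3 of the 3 values shown sit, so none can be ranked against another. Among the compounds with values here, the one step between compounds that differ in a single place, a step that the two limits leave unreadable from compound 2 to compound 3, is likewise unreadable. Compound 4 `CCCNC(=O)Nc1cc2nc(C3CCCCC3)[nH]c2cc1N(CC)CC` differs from compound 1 by propylamino in place of 2-(2-methoxyethoxy)ethoxy on a carbonyl carbon. No measured step touches this change, and the only step shown is unreadable, so no direction or size can be drawn from it. Within the data shown here, compound 4 is therefore expected to show no step in this assay that rises out of the limit, a step that the limit leaves unreadable from compound 1 to compound 4. For compound 4 the estimate is 120 ug/mL, in a range from 60 ug/mL to 250 ug/mL.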

Compound 4, half-maximal inhibitory concentration: > 100 ug/mL
Compound 4: a limit, no number; the forecaster's own chance of this, stated with the estimate: 85%; the middle value lies beyond the limit too.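

Compound 1 and compound 4 both end at a limit rather than a number, so no step can be read between them: the limit of > 100 ug/mL in this assay, at which 4 of the 4 values shown sit. The compounds shown leave open how far each lies beyond that limit, and whether any single change alters the result in this assay at all.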